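The source may hold more compounds than are shown below. What is called first, only, known or untested is meant among the compounds shown, and "the series" means these compounds.

Working notes on the series. Compound 2 `CC(C)OC(=O)Nc1nc2ccc(NC(=O)c3c(Cl)cccc3Cl)cc2s1` gives 0.0026 ug/mL in a functional assay on WI-38 VA13 cells (Homo sapiens) for cytotoxicity (a higher number here means that more compound is needed for the effect, a lower number that less compound is needed), and holds the lowest of the two numbers recorded so far; its nearest neighbour, compound 1 `O=C(Nc1ccc2nc(NC(=O)C3CCCCC3)sc2c1)c1c(Cl)cccc1Cl`, gives 0.015 ug/mL. For the measured compounds named here, the single step measured between them, a 5.8-fold lower number from compound 1 to compound 2 (0.76 log units; beyond the scatter), concerns a change on the same carbonyl carbon as the one now in question. Compound 3 `O=C(NCc1ccccc1)Nc1nc2ccc(NC(=O)c3c(Cl)cccc3Cl)cc2s1` is not yet measured in this assay. It differs from compound 2 by benzylamino in place of isopropoxy on a carbonyl carbon. The measured step bears on it only loosely: it shows that a change at that carbonyl carbon can move the number by a modest amount, but the exchange there was isopropoxy for cyclohexyl, not benzylamino for isopropoxy. Going by the values given here, with no closer precedent, the expected step of a 2.3-fold higher number from compound 2 to compound 3 (0.36 log units; beyond the scatter) is small, within or just beyond the scatter, and its direction is uncertain. Compound 3 is thus expected to give about 0.006 ug/mL, with a range of 0.0015 ug/mL to 0.025 ug/mL.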

Compound 3, half-maximal effective concentration: 0.15 ug/mL
Compound 3: the middle estimate sits 25-fold (1.40 log units) below what was measured; the measured number lies above the stated range.
By their numbers in this assay, from the lowest: compound 2; then compound 1; then compound 3.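

In this assay, for the compounds shown here, the carbonyl carbon on the amide-type nitrogen proves more sensitive than the earlier pair could show: benzylamino in place of isopropoxy gives a 58-fold higher number from compound 2 to compound 3 (1.76 log units; beyond the scatter) and is a large step, whereas the one earlier exchange there was modest. Benzylamino in place of cyclohexyl gives a 10-fold higher number from compound 1 to compound 3 (1.00 log units; beyond the scatter) as well, so the rise appears against both earlier groups and compound 3 carries the highest number of the three. No measurement bearing on the cause of this rise is available.

Benzylamino brings both a nitrogen with its hydrogen and an aromatic ring to this carbonyl carbon, and the compounds shown do not separate the two. Benzyloxy on the same carbon would keep the ring without that nitrogen, while isopropylamino would keep the nitrogen without the ring.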